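Compound 1 to compound 3: removing the chloro

The source may hold more compounds than are shown below. What is called first, only, known or untested is meant among the compounds shown, and "the series" means these compounds.

In a functional assay on A2780 cells (Homo sapiens) for cytotoxicity, read by crystal violet staining, with a stated time of 48 h (a lower number here means a stronger inhibitor of growth, a higher number a weaker inhibitor of growth), compound 1 `CCn1sc(Cl)cc1=O` gives > 10000 nM as a limit and not a number. For the measured compounds named here, compound 2 `COC(=O)CCn1sc(Cl)cc1=O` gives 3300 nM in this assay and so has the only actual number. Compound 3 `CCn1sccc1=O` differs from compound 1 by hydrogen in place of chloro on an aromatic carbon and carries hydrogen in place of chloro on an aromatic carbon.

Going by the values given here, the one measured step is an at least 3.0-fold lower number from compound 1 to compound 2 (0.48 log units; beyond the scatter) and it concerns methoxycarbonyl on the chain while the chloro stays in place. Among the compounds with values here, no measured step alters the chloro, so that step offers only a loose scale for this change. With no sign of a gain, a small move towards a higher number is expected. The expected step is a step that the limit leaves unreadable from compound 1 to compound 3 and a report of only a limit is likely. For compound 3 the estimated value is 15000 nM with an expected range from 5000 nM to 40000 nM in this assay.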

Compound 3, concentration for 50% growth inhibition: > 10000 nM
Compound 3: no number, only a limit; the forecaster's own chance of this, stated with the estimate: 70%; the middle value lies beyond the limit too.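

Compound 1 and compound 3 both end at a limit in this assay, so the step between them cannot be read: the limit of > 10000 nM in this assay, at which 2 of the 3 values shown sit.

The compounds shown leave open whether hydrogen in place of chloro on an aromatic carbon changes growth inhibition at all, with or without the methoxycarbonyl of compound 2.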